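Replacing a formyl with an isopropyl on a pyridine N-oxide ether

The compounds below may be only part of what the source reports. "The series", "measured", "known", "first", "only" and "open" are said of these compounds alone.

Of the compounds shown here, three that share one core have been tested in a functional assay on the whole organism with Mus musculus as the target, in the maximal electroshock model, with a stated time of 30 min; on this read-out higher numbers stand for an effect only at larger amounts of compound and lower numbers for an effect already at smaller amounts. Compound 1, `[O-][n+]1cccc(Oc2ccccc2)c1`, gives 100 mg/kg. Compound 2, `Cc1cc[n+]([O-])cc1Oc1ccccc1`, gives 30 mg/kg. Compound 3, `O=Cc1cc[n+]([O-])cc1Oc1ccccc1`, gives 300 mg/kg, the highest of the three numbers, so it is the one that needs the largest amount of compound for an effect; its nearest neighbour is compound 1, and the gap to compound 2 is larger, as the step of a 10-fold higher number from compound 2 to compound 3 (1.00 log units; beyond the scatter) shows.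

Compound 4, `CC(C)c1cc[n+]([O-])cc1Oc1ccccc1`, has not yet been measured. It differs from compound 3 in one place: isopropyl in place of formyl on an aromatic carbon, on an aromatic carbon of a six-membered aromatic ring with one nitrogen, opposite the ring nitrogen.

Among the compounds with values here, two measured steps bear on this change. Putting a formyl in place of a methyl gave a 10-fold higher number from compound 2 to compound 3 (1.00 log units; beyond the scatter), and putting a formyl in place of a hydrogen gave a 3.0-fold higher number from compound 1 to compound 3 (0.48 log units; beyond the scatter). Both show that the formyl goes with a higher number, and the methyl of compound 2 goes with a lower one, as the step of a 3.3-fold lower number from compound 1 to compound 2 (0.52 log units; beyond the scatter) shows. Compound 4 carries an alkyl group again, isopropyl rather than methyl, so the expected step of a 7.5-fold lower number from compound 3 to compound 4 (0.88 log units; beyond the scatter) should be a return toward lower numbers. Compound 4 is therefore estimated at 40 mg/kg, in the range 10 mg/kg to 150 mg/kg.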

Compound 4, minimum effective dose: 30 mg/kg
Beside the measured number, compound 4's estimate is 1.3-fold (0.12 log units) above it; low and high end bracket the measured number.
By their numbers in this assay, from the lowest: compounds 2 and 4 (each within the scatter of the next); then compound 1; then compound 3.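

In this assay, the place opposite the ring nitrogen now carries a second, larger alkyl group, and exchanging the formyl for isopropyl gives a 10-fold lower number from compound 3 to compound 4 (1.00 log units; beyond the scatter) as the step, about as large as any seen in this small set. The size of the alkyl group makes no visible difference here: the exchange of methyl for isopropyl gives no change at the digits printed from compound 2 to compound 4 (within the scatter) as its result, so the additional carbons of isopropyl neither help nor harm on this read-out. Measured against the compound with only hydrogen at this place, isopropyl gives a 3.3-fold lower number from compound 1 to compound 4 (0.52 log units; beyond the scatter) as its step, matching a 3.3-fold lower number from compound 1 to compound 2 (0.52 log units; beyond the scatter) for methyl, while no measurement at hand explains why both alkyl groups part ways with the formyl.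

What the compounds shown leave open is whether a longer chain such as butyl would keep the number this low or whether the trend stops somewhere beyond isopropyl. From the compounds shown here alone, it is equally open whether an amine or a carboxylic acid at this place would behave like the alkyl groups or like the formyl.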